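This account rests on a few compounds, and the source may have more. Where it says the series, first, only, none or still open, it means among the compounds named here.

Measured so far in an ADME assay for pharmacokinetics, read by HPLC, in phosphate buffer, with a stated time of 72 h, at pH 7.4, tested at 250 uM; on this read-out higher numbers stand for a longer-lived compound and lower numbers for a shorter-lived compound:

Compound 1 `C=CC(=O)Oc1cc(C(F)(F)F)cc(C(F)(F)F)c1`. In this assay compound 1 gives < 0.017 h, which is a limit of the assay and not a number.
Compound 2 `C=CS(=O)(=O)c1cc(C(F)(F)F)cc(C(F)(F)F)c1`. In this assay compound 2 gives < 0.017 h, again a limit of the assay rather than a number.
Compound 3 `C#Cc1cc(C(F)(F)F)cc(C(F)(F)F)c1`. In this assay compound 3 gives 2.4 h.

For the measured compounds named here, compound 3 therefore stands as the only true number in the set; the other two results sit at the limit of < 0.017 h in this assay, at which 2 of the 3 values shown sit. The measured steps that reach compound 3 are both large: an at least 140-fold higher number from compound 1 to compound 3 (2.14 log units; beyond the scatter) and an at least 140-fold higher number from compound 2 to compound 3 (2.14 log units; beyond the scatter). The step between the two limit values, a step that the two limits leave unreadable from compound 1 to compound 2, cannot be sized.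

Compound 4 `O=C(CBr)c1cc(C(F)(F)F)cc(C(F)(F)F)c1` is the next one to be measured. The change is (bromomethyl)carbonyl in place of ethynyl on an aromatic carbon. No measured pair carries the (bromomethyl)carbonyl group, so the step from compound 3 to compound 4 is not directly covered by any shown step. What is shown is that compound 3 is the only compound of the three to give a readable number, and that each departure from ethynyl among the measured compounds fell to the limit. On that basis a lower number for compound 4 is expected, with the size uncertain, and the estimated step is a 6.0-fold lower number from compound 3 to compound 4 (0.78 log units; beyond the scatter). For compound 4 in this assay the expected value is 0.4 h, estimated to lie between 0.017 h and 5 h.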

Compound 4, half-life: < 0.017 h
Compound 4 was reported as a limit; the forecaster's own chance of this, stated with the estimate: 35%; middle value at least 23-fold (1.37 log units) from the limit.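

In this assay, the change from ethynyl to (bromomethyl)carbonyl on this aromatic carbon gives an at least 140-fold lower number from compound 3 to compound 4 (2.14 log units; beyond the scatter), a large step and the first one measured in this direction, with ethynyl as the group that leaves. For the compounds shown here, compound 3 is now the only compound of the four with a readable number, so three different groups at this place, meta to two trifluoromethyl groups, end at the limit and ethynyl is the sole exception. The steps among compound 1, compound 2 and compound 4 cannot be read, so the series gives no order among these three groups, and the result for compound 4 adds a further compound to the floor of the read-out: the limit of < 0.017 h in this assay, at which 3 of the 4 values shown sit.

Going by these compounds, whether a nitrile or a simple amide on the same aromatic carbon would give a readable half-life remains open, and so does how far any of the three limit compounds lies beyond the limit. Also open, on these data alone, is whether ethynyl would keep a readable half-life with an amine or a carboxylic acid in place of a trifluoromethyl group on the shared core.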